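Removing the Amino Group from the Core of Compound 1

The source may hold more compounds than are shown below. What is called first, only, known or untested is meant among the compounds shown, and "the series" means these compounds.

Compound 1 `Nc1n[nH]c2cc(-c3ccc(=O)n(Cc4ccccc4F)c3)ccc12` and compound 2 `Nc1n[nH]c2cc(-c3ccc(=O)n(Cc4cccc(Cl)c4)c3)ccc12` share a core and differ only in the group on a saturated chain carbon bound to an aromatic nitrogen. In an assay for inhibition of MAP kinase-interacting serine/threonine-protein kinase 1 (Homo sapiens), read by luminescence and ADP-Glo, with a stated time of 2 h (a higher number here means a weaker inhibitor, a lower number a stronger inhibitor), compound 1 gives 12 nM, the higher of the two numbers, and compound 2 gives 11 nM; the step of a 1.1-fold lower number from compound 1 to compound 2 (0.04 log units; within the scatter) is within the scatter. Compound 3 `O=c1ccc(-c2ccc3cn[nH]c3c2)cn1Cc1ccccc1F` is compound 1 with hydrogen in place of amino on an aromatic carbon. Within the data shown here, no measured step touches this position, so the data give no guide to its size. As the change removes a hydrogen-bond donor and acceptor from the core, compound 3 is expected to be a weaker inhibitor, estimated at 300 nM with a range from 50 nM to 3000 nM. That estimate means a 25-fold higher number from compound 1 to compound 3 (1.40 log units; beyond the scatter).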

Compound 3, half-maximal inhibitory concentration: 47 nM
Estimate against measurement, compound 3: 6.4-fold (0.81 log units) above; measured number below the stated range.
By their numbers in this assay, from the lowest: compounds 2 and 1 (each within the scatter of the next); then compound 3.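

In this assay, among these compounds, replacing the amino group with hydrogen gives a 3.9-fold higher number from compound 1 to compound 3 (0.59 log units; beyond the scatter) and this is the first change here to move the number beyond the scatter. The amino group on this aromatic carbon therefore contributes modestly, but it is not essential, since compound 3 still gives 47 nM in this assay as a nanomolar inhibitor. Nothing available explains the size of this step.

As far as these compounds go, it remains open whether a methyl, hydroxyl or methylamino group on this carbon would match the amino group. From the compounds shown here alone, it is also open whether the same step would hold with the 3-chlorophenyl group of compound 2.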